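A few compounds are considered here, and "the series" means these few. Any claim that something is new, unique, unknown or untested is made for them only; others in the source may bear on it.

Compound 1 `O=C(NCCCNc1nc(Nc2cnn(C3CC3)c2)ncc1C1CC1)C1CCC1` gives 130 nM in an assay on RAW264.7 cells for inhibition of serine/threonine-protein kinase TBK1 (Mus musculus), read by ELISA, with stated times of 30 min and 6 h; a higher number here means a weaker inhibitor, a lower number a stronger inhibitor. Compound 2 `O=C(NCCCNc1nc(Nc2cccc(F)c2)ncc1C1CC1)C1CCC1` gives 1300 nM in this assay.

For the measured compounds named here, of the two compounds measured so far, compound 2 shows the higher number, that is, the weaker inhibition, and its only neighbour is compound 1. The two differ in the group attached to the nitrogen on the shared core, and that exchange gave a 10-fold higher number from compound 1 to compound 2 (1.00 log units; beyond the scatter), a step beyond the usual scatter, showing that this group influences the read-out noticeably.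

Compound 3 `CN(C)Cc1ccc(Nc2ncc(C3CC3)c(NCCCNC(=O)C3CCC3)n2)cc1` is the next compound to be measured. It differs from compound 2 by 4-((dimethylamino)methyl)phenyl in place of 3-fluorophenyl on a nitrogen on an aromatic ring. Going by the values given here, no measured step covers this particular exchange, so the only guide is that the group in this place moved the number by a 10-fold higher number from compound 1 to compound 2 (1.00 log units; beyond the scatter) between compound 1 and compound 2. A change of comparable size, in either direction, is therefore plausible. For compound 3 the expected step is a 3.3-fold lower number from compound 2 to compound 3 (0.51 log units; beyond the scatter), towards a somewhat lower number. The estimate for compound 3 is 400 nM, with a range from 80 nM to 2000 nM.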

Compound 3, half-maximal inhibitory concentration: 550 nM
Beside the measured number, compound 3's estimate is 1.4-fold (0.14 log units) below it; measured number inside the range.
By their numbers in this assay, from the lowest: compound 1; then compound 3; then compound 2.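

Replacing 3-fluorophenyl with 4-((dimethylamino)methyl)phenyl on the nitrogen gives a 2.4-fold lower number from compound 2 to compound 3 (0.37 log units; beyond the scatter) in this assay, so this place accepts the larger group, and the two carbon-only aromatic rings do not give the same result. Compared with the 1-cyclopropyl-1H-pyrazol-4-yl group, however, the new group gives a 4.2-fold higher number from compound 1 to compound 3 (0.63 log units; beyond the scatter), so among these three compounds, both groups with a six-membered aromatic ring of carbon give a higher number than the pyrazole group, and no compound shown goes against this. Nothing available gives a cause for either step.

Going by these compounds, it remains open whether the lower number of compound 3 relative to compound 2 belongs to the dimethylamino group or to the rest of the new group, which a plain 4-methylphenyl group or a morpholine in place of the dimethylamine could help to separate. On these data alone, it is equally open whether the lower number of compound 1 survives with a methyl group in place of the cyclopropyl on the pyrazole.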